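Sulfonyl Series: Piperidinyloxy Replaces the Fluoropyridyl Group

The source may report more compounds than this note shows. Statements on the series, on what has been measured and on what is new or still open speak of the compounds shown alone.

Measured compounds:
compound 1 `CCCCCc1ccc(S(=O)(=O)c2c(C)cc(C)cc2C)cc1`: > 300000 nM
compound 2 `Cc1cc(C)c(S(=O)(=O)c2ccc(-c3ccc(F)nc3)cc2)c(C)c1`: > 300000 nM

In an assay on isolated protein for antagonist activity at Rap guanine nucleotide exchange factor 4 (Homo sapiens), read by fluorescence and cAMP accumulation (on this read-out lower numbers stand for stronger inhibition and higher numbers for weaker inhibition), compound 1 gives > 300000 nM, which is a limit of the assay and not a number. In this assay compound 2 likewise gives > 300000 nM, again a limit. The step that the two limits leave unreadable from compound 1 to compound 2 therefore cannot be read. Compound 2 stands at the limit of > 300000 nM in this assay, at which 2 of the 2 values shown sit.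

Compound 3 `Cc1cc(C)c(S(=O)(=O)c2ccc(OC3CCNCC3)cc2)c(C)c1` differs from compound 2 in one place: (piperidin-4-yl)oxy in place of 6-fluoropyridin-3-yl on an aromatic carbon. Going by the values given here, the only measured step, from compound 1 to compound 2, is unreadable, so no measured step gives a readable size for the change now being followed, and no direction can be drawn from the two limits.

Compound 3 is therefore expected to sit near 200000 nM, with a range from 20000 nM to 1000000 nM. This estimate amounts to an expected step of an at least 1.5-fold lower number from compound 2 to compound 3 (0.17 log units; that floor lies within the scatter).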

Compound 3, half-maximal inhibitory concentration: > 300000 nM
Compound 3 gave a limit, no number (the forecaster's own chance of this, stated with the estimate: 65%); middle value at least 1.5-fold (0.17 log units) away from the limit.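

In this assay, going by these compounds alone, compound 3 gives > 300000 nM, which is a limit and not a number, so no step to it from compound 1 or compound 2 can be read. The compounds shown leave open how pentyl, 6-fluoropyridin-3-yl and (piperidin-4-yl)oxy rank against one another.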